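Methylamino in place of methoxy on a carbonyl carbon

The source may report more compounds than this note shows. Statements on the series, on what has been measured and on what is new or still open speak of the compounds shown alone.

- compound 1 `COC(=O)C[C@H](NC(=O)OC(C)(C)C)C(=O)N(Cc1ccccc1)C1(C(=O)NCc2ccccc2)CCN(Cc2ccccc2)CC1` with 20000 nM
- compound 2 `COC(=O)C[C@H](NC(=O)OC(C)(C)C)C(=O)N(Cc1ccccc1)C1(C(=O)NC2CCCCC2)CCN(Cc2ccccc2)CC1` with 21000 nM

In a functional assay on HeLa cells (Homo sapiens) for inhibition, with a stated time of 72 h (on this read-out higher numbers stand for weaker inhibition and lower numbers for stronger inhibition), compound 1 gives 20000 nM and sits level with compound 2 at 21000 nM, since the two lie within the scatter of each other. For the measured compounds named here, the only measured step, cyclohexyl in place of benzyl on an amide-type nitrogen, is a 1.1-fold higher number from compound 1 to compound 2 (0.02 log units; within the scatter) and stays within the scatter. That step lies at a different place, so it bears only indirectly on compound 3 `CNC(=O)C[C@H](NC(=O)OC(C)(C)C)C(=O)N(Cc1ccccc1)C1(C(=O)NCc2ccccc2)CCN(Cc2ccccc2)CC1`, which has methylamino in place of methoxy on a carbonyl carbon. Going by the values given here, no measurement yet tests a change at this place, so the direction is open. Going by the small size of a 1.1-fold higher number from compound 1 to compound 2 (0.02 log units; within the scatter), no step beyond the scatter is expected in this assay. The estimate is a 1.1-fold higher number from compound 1 to compound 3 (0.04 log units; within the scatter) as an expected step. For compound 3 the estimated value is 22000 nM, with an expected range from 8000 nM to 60000 nM.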

Compound 3, half-maximal inhibitory concentration: 84000 nM
Beside the measured number, compound 3's estimate is 3.8-fold (0.58 log units) below it; the measured number lies above the stated range.
By their numbers in this assay, from the lowest: compounds 1 and 2 (each within the scatter of the next); then compound 3.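

In this assay, methylamino in place of methoxy on a carbonyl carbon gives a 4.2-fold higher number from compound 1 to compound 3 (0.62 log units; beyond the scatter), so this position responds to change, whereas the step at the other place, a 1.1-fold higher number from compound 1 to compound 2 (0.02 log units; within the scatter), did not. Both groups count 2 heavy atoms, yet this exchange of oxygen for nitrogen, which also brings in a hydrogen-bond donor, is enough to weaken inhibition. Nothing at hand explains why methylcarbamoyl does worse than methoxycarbonyl here.

The compounds shown leave open whether the amide hydrogen matters or whether any replacement of methoxy at this place gives the same result, a question that a dimethylamino group, an ethoxy group or a carboxylic acid on the same carbonyl carbon could address. They also leave open whether the same change would weaken inhibition on compound 2, which carries the cyclohexyl group.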